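The source may report more compounds than this note shows. Statements on the series, on what has been measured and on what is new or still open speak of the compounds shown alone.

Measured in a functional assay on the whole organism (strain Wistar) for inhibition, with Rattus norvegicus as the target, read by paw edema, with stated times of 30 min and 2 h, at a dose of 20 mg/kg; on this read-out lower numbers stand for less inhibition and higher numbers for more inhibition at the one dose given (going by the name of the read-out):
compound 1 `CCOC(=O)C1=C(C)NC(C)=C(C(=O)OCC)C1c1ccc(OCC(=O)Nc2nc3ccccc3s2)cc1` gives 64.5%
compound 2 `CCOC(=O)C1=C(C)NC(C)=C(C(=O)OCC)C1c1ccc(OCC(=O)NNC(=O)c2ccccc2)cc1` gives 44.5%
compound 3 `CCOC(=O)C1=C(C)NC(C)=C(C(=O)OCC)C1c1ccc(OCC(=O)n2nc(C)cc2C)cc1` gives 46.1%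

Compound 3 stands within the scatter of compound 2 (a number 1.6 percentage points higher from compound 2 to compound 3 (within the scatter)) and below compound 1 beyond the scatter (a number 18.4 percentage points lower from compound 1 to compound 3 (beyond the scatter)). Compound 4 `CCOC(=O)C1=C(C)NC(C)=C(C(=O)OCC)C1c1ccc(OCC(=O)NNC(=O)CCC(=O)O)cc1` differs from compound 3 in one place: a group of 9 heavy atoms (4 carbon, 2 nitrogen, 3 oxygen; no ring) in place of a group of 7 heavy atoms (5 carbon, 2 nitrogen; one five-membered aromatic ring with 2 hetero atoms), on a carbonyl carbon. Within the data shown here, the step that bears on this change is the one from compound 2, whose group on the same carbonyl carbon is benzamidoamino, also without a ring; that step, a number 1.6 percentage points higher from compound 2 to compound 3 (within the scatter), stayed within the scatter. For compound 4 no step beyond the scatter is therefore expected in this assay, with at most a slight lowering, because the step of a number 1.6 percentage points higher from compound 2 to compound 3 (within the scatter) was itself within the scatter. Compound 4 is estimated at 42%, range 28% to 56%. The expected step is a number 4.1 percentage points lower from compound 3 to compound 4 (within the scatter).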

Compound 4, a percentage reported as inhibition, in the whole organism at one dose (the size of the read-out at that dose, not a potency): 57.8%
Compound 4: the middle estimate sits 15.8 percentage points below what was measured, outside the stated range (above it).
By their numbers in this assay, from the lowest: compounds 2 and 3 (each within the scatter of the next); then compounds 4 and 1 (each within the scatter of the next).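

On the carbonyl carbon of the acyl hydrazide, 2-carboxyethyl in place of phenyl moves the number clearly (a number 13.3 percentage points higher from compound 2 to compound 4 (beyond the scatter)), so this position does respond to the group it carries, which the earlier pair of compound 2 and compound 3 did not show. The ring-free group also stands clear of the dimethylpyrazole (a number 11.7 percentage points higher from compound 3 to compound 4 (beyond the scatter)), yet stays within the scatter of the benzothiazole amide (a number 6.7 percentage points lower from compound 1 to compound 4 (within the scatter)), so a ring is not required here for a high number. Nothing available explains this rise.

Open, as far as these compounds go, is whether the carboxylic acid or the chain itself carries the step over phenyl. A methyl ester, an amine or a longer chain on the same carbonyl carbon would separate the two.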